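A few compounds are considered here, and "the series" means these few. Any claim that something is new, unique, unknown or untested is made for them only; others in the source may bear on it.

Measured so far in a functional assay on MCF7 cells (Homo sapiens) for inhibition, read by MTT assay, with a stated time of 24 h; a lower number here means a stronger inhibitor, a higher number a weaker inhibitor:

Compound 1 `CCOC(=O)C1=Cc2ccccc2OC1(OCc1cc(-c2ccc(OC)cc2)no1)C(F)(F)F` gives > 150000 nM, which is a limit of the assay rather than a number.
Compound 2 `CCOC(=O)C1=Cc2ccccc2OC1(OCc1cn(CC(=O)Nc2cccc(F)c2)nn1)C(F)(F)F` gives > 150000 nM, again a limit of the assay.
Compound 3 `COc1ccc(-c2cc(COC3(C(F)(F)F)Oc4ccccc4C=C3C(=O)O)on2)cc1` gives 35200 nM.

Compound 1 therefore stands at the edge of what this assay can report, and it shares that position with compound 2, since (the limit of > 150000 nM in this assay, at which 2 of the 3 values shown sit). Going by the values given here, the only step within this set that connects two compounds differing in one place is an at least 4.2-fold lower number from compound 1 to compound 3 (0.62 log units; beyond the scatter), namely hydrogen in place of ethyl on an oxygen next to a carbonyl group; that change is far from the part of the structure altered here.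

Compound 4 `CCOC(=O)C1=Cc2ccccc2OC1(OCc1cc(-c2cccc(C(F)(F)F)c2)no1)C(F)(F)F` differs from compound 1 by 3-(trifluoromethyl)phenyl in place of 4-methoxyphenyl on an aromatic carbon. Among the compounds with values here, no measured step touches this aromatic substituent, so nothing in the data points toward a movement in either direction, and the step from compound 1 is expected to stay within the usual scatter. Compound 4 is therefore expected to sit at about 150000 nM, with a plausible range from 40000 nM to 400000 nM, which amounts to an expected step of a number no higher from compound 1 to compound 4 (the limit leaves the size open). Given that compound 1 itself reached only the limit, it is likely that compound 4 will also be reported only as a limit.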

Compound 4, half-maximal inhibitory concentration: 22100 nM
Compound 4: the middle estimate sits 6.8-fold (0.83 log units) above what was measured; the whole stated range lies above it.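

Replacing 4-methoxyphenyl with 3-(trifluoromethyl)phenyl on this aromatic carbon gives an at least 6.7-fold lower number from compound 1 to compound 4 (0.83 log units; beyond the scatter) in this assay, which shows that the read-out responds to the aromatic group at this position even with the ethyl ester kept. Going by these compounds alone, until this result, the only readable step was the change at the ester, an at least 4.2-fold lower number from compound 1 to compound 3 (0.62 log units; beyond the scatter), so the aromatic group is a second place where a change gives a measured number rather than a limit. The full size of the new step remains unknown because compound 1 stands at the edge of what the assay can report: the limit of > 150000 nM in this assay, at which 2 of the 4 values shown sit.

Since the substituent and its place on the phenyl ring differ together between compound 1 and compound 4, the compounds shown cannot separate the effect of the trifluoromethyl group from that of its location, and a phenyl ring carrying a chlorine atom or an amine would widen the comparison. As far as these compounds go, it also remains open whether 3-(trifluoromethyl)phenyl and the carboxylic acid of compound 3 would add up when combined in one compound.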